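The source may report more compounds than this note shows. Statements on the series, on what has been measured and on what is new or still open speak of the compounds shown alone.

In a functional assay on K562 cells (Homo sapiens) for antiproliferative activity, read by MTT assay, with a stated time of 72 h (a higher number here means a weaker inhibitor, a lower number a stronger inhibitor), the measured compounds read:

- compound 1 `COc1cc(C(=O)c2sc3ccccc3c2-c2ccc(F)cc2)cc(OC)c1OC`: 2100 nM
- compound 2 `COc1ccc(OC)c(-c2c(C(=O)c3cc(OC)c(OC)c(OC)c3)sc3ccccc23)c1`: > 10000 nM (a limit of the assay)
- compound 3 `COc1cc(C(=O)c2sc3ccccc3c2Nc2ccccc2)cc(OC)c1OC`: 2300 nM

For the measured compounds named here, compound 3 gives 2300 nM and has only one neighbour with a true number. The two stand level, the step being a 1.1-fold higher number from compound 1 to compound 3 (0.04 log units; within the scatter), within the scatter. The reading for compound 2 is a limit, so only a minimum size is known for the steps that touch it.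

Compound 4 `CCOc1ccc(Nc2c(C(=O)c3cc(OC)c(OC)c(OC)c3)sc3ccccc23)cc1` keeps the shared core and turns the anilino of compound 3 into (4-ethoxyphenyl)amino: ethoxy in place of hydrogen on an aromatic carbon, para to a large group (ethoxy in place of hydrogen on an aromatic carbon). Going by the values given here, no measured step adds ethoxy, so the evidence is indirect. Replacing 4-fluorophenyl with anilino changed nothing beyond the scatter. Among the compounds with values here, the one aryl group bearing alkoxy substituents gave a loss, an at least 4.7-fold higher number from compound 1 to compound 2 (0.67 log units; beyond the scatter), and its removal gave an at least 4.3-fold lower number from compound 2 to compound 3 (0.63 log units; beyond the scatter). That group is 2,5-dimethoxyphenyl, however, which differs from the new group in both its substituents and its attachment, so it is a weak guide. No firm direction follows, and the expected change is a 1.5-fold lower number from compound 3 to compound 4 (0.19 log units; within the scatter), an estimate that stays within the scatter, though with wide uncertainty in this assay. For compound 4 the estimated value is 1500 nM, with an expected range of 200 nM to 9000 nM.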

Compound 4, half-maximal inhibitory concentration: 200 nM
For compound 4 the middle estimate is 7.5-fold (0.88 log units) above the measured one; the measured number falls inside the stated range.
By their numbers in this assay, from the lowest: compound 4; then compounds 1 and 3 (each within the scatter of the next). At a limit, above all of these: compound 2.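

In this assay, adding ethoxy to the anilino of compound 3 gives a 12-fold lower number from compound 3 to compound 4 (1.06 log units; beyond the scatter), a large step at a place where the earlier swap of 4-fluorophenyl for anilino gave only a 1.1-fold higher number from compound 1 to compound 3 (0.04 log units; within the scatter). For the compounds shown here, the (4-ethoxyphenyl)amino group also stands clear of 4-fluorophenyl, with an 11-fold lower number from compound 1 to compound 4 (1.02 log units; beyond the scatter), so compound 4 is the first compound here to separate from the level pair of compounds 1 and 3, and the loss seen with 2,5-dimethoxyphenyl does not carry over to every alkoxy-bearing aryl group on this carbon of the shared core. Against that 2,5-dimethoxyphenyl group the change reads an at least 50-fold lower number from compound 2 to compound 4 (1.69 log units; beyond the scatter), which gives a minimum size only, since compound 2 stands at a limit and not at a number: the limit of > 10000 nM in this assay, at which 1 of the 4 values shown sits.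

The compounds shown leave open whether methoxy, a hydroxyl group or a longer chain such as butoxy at this place would give a step of the same size. They also leave open whether ethoxy would do the same on a phenyl attached directly to the shared core, standing where compound 1 carries its fluorine.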